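Swapping 3-fluorophenyl for 4-methylphenyl on a shared core

The compounds below may be only part of what the source reports. "The series", "measured", "known", "first", "only" and "open" are said of these compounds alone.

- Compound 1 `Fc1cc(F)cc(-c2nc3cccnc3n2C2CCCC2)c1`: 138 nM
- Compound 2 `FC(F)(F)c1cc(-c2nc3cccnc3n2C2CCCC2)cc(C(F)(F)F)c1`: 112 nM
- Compound 3 `Fc1cccc(-c2nc3cccnc3n2C2CCCCC2)c1`: 342 nM

These values come from a functional assay on MDA-MB-231 cells (Homo sapiens) for cytotoxicity, read by MTT assay, with a stated time of 24 h; a higher number here means a weaker inhibitor, a lower number a stronger inhibitor. Compound 3 has the highest number of the three, making it the weakest inhibitor here, and its gap to both compound 1 and compound 2 lies beyond the scatter. Compound 4 `Cc1ccc(-c2nc3cccnc3n2C2CCCCC2)cc1` has 4-methylphenyl in place of 3-fluorophenyl on an aromatic carbon. For the measured compounds named here, no two measured compounds differ in only one place, so the data give no direct measure of this swap. The estimated change, a 1.1-fold lower number from compound 3 to compound 4 (0.06 log units; within the scatter), stays within the usual scatter of this assay. The estimate for compound 4 is 300 nM, with an expected range of 120 nM to 750 nM.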

Compound 4, half-maximal inhibitory concentration: 7000 nM
The estimate for compound 4 lay 23-fold (1.37 log units) below the measured number; the measured number lies above the stated range.
By their numbers in this assay, from the lowest: compounds 2 and 1 (each within the scatter of the next); then compound 3; then compound 4.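

In this assay, replacing 3-fluorophenyl with 4-methylphenyl at this position brings a 20-fold higher number from compound 3 to compound 4 (1.31 log units; beyond the scatter) on the shared core. This position is therefore sensitive to the change, even though neither group carries a hydrogen-bond donor, a hydrogen-bond acceptor or a net charge. Nothing available here accounts for the large drop in potency. The swap alters both the substituent and its place on the phenyl ring, so the two effects remain entangled. Going by these compounds, how 4-fluorophenyl, 3-methylphenyl or a phenyl bearing an amine would behave here remains open.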